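The compounds below may be only part of what the source reports. "The series", "measured", "known", "first", "only" and "open" are said of these compounds alone.

Measured so far in an ADME assay on microsomes from liver (Mus musculus, strain CD-1) for metabolic stability, read by LC-MS, tested at 2 uM; on this read-out higher numbers stand for a longer-lived compound and lower numbers for a shorter-lived compound
- compound 1 `Cn1cc(NC(=O)c2ccncc2Nc2cc(-c3ccc4ccn(C)c4c3)c3nccnc3c2)cn1` gives 0.2 h
- compound 2 `CC(=O)N1CCCC(NC(=O)c2ccncc2Nc2cc(-c3ccc4ccn(C)c4c3)c3nccnc3c2)C1` gives 0.4 h

Compound 2 stands level with compound 1 within the scatter, and no other measured value is available for comparison. Compound 3 `CN1CC(NC(=O)c2ccncc2Nc2cc(-c3ccc4ccn(C)c4c3)c3nccnc3c2)CCC1=O` carries 1-methyl-6-oxopiperidin-3-yl in place of 1-acetylpiperidin-3-yl on an amide-type nitrogen. Among the compounds with values here, one measured step bears on this change, made at the same place (a 2.0-fold higher number from compound 1 to compound 2 (0.30 log units; within the scatter)). It lies within the scatter, so no step beyond the scatter is expected in this assay here. The expected step (no change at the digits printed from compound 2 to compound 3 (within the scatter)) stays within the scatter. For compound 3 the estimate is 0.4 h with an expected range from 0.2 h to 0.8 h on this read-out.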

Compound 3, half-life: 0.75 h
Beside the measured number, compound 3's estimate is 1.9-fold (0.27 log units) below it; measured number inside the range.
By their numbers in this assay, from the lowest: compounds 1, 2 and 3 (each within the scatter of the next, the first and the last beyond it).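

On the amide-type nitrogen, this assay now shows a step beyond the scatter, though a modest one: a 3.8-fold higher number from compound 1 to compound 3 (0.57 log units; beyond the scatter), which separates 1-methyl-6-oxopiperidin-3-yl from 1-methyl-1H-pyrazol-4-yl. The swap from 1-acetylpiperidin-3-yl reads a 1.9-fold higher number from compound 2 to compound 3 (0.27 log units; within the scatter), so these two groups are not separated. No measurement at hand accounts for either step. Still open, going by these compounds, is how a primary amine or a carboxylic acid on the ring of this substituent would read, and whether the step from compound 1 to compound 3 holds on a changed core.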